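Removing One Methyl from the Amine of Compound 1

This account rests on a few compounds, and the source may have more. Where it says the series, first, only, none or still open, it means among the compounds named here.

Measured compounds:
Compound 1: `COc1ccc(Cc2nc(-c3cc(Br)c(OCCCN(C)C)c(Br)c3)c[nH]c2=O)cc1Br` — 6900 nM
Compound 2: `COc1ccc(Cc2nc(-c3cc(Br)c(OCCCN(C)C)c(Br)c3)cnc2Cl)cc1Br` — "not determined" (no result reported)

The study centres on compound 1, whose activity was read in a functional assay on MCF7 cells (Homo sapiens) for inhibition, read by MTT assay, with a stated time of 24 h (on this read-out higher numbers stand for weaker inhibition and lower numbers for stronger inhibition), where compound 1 gives 6900 nM. Among the measured compounds shown here, this is the only number in the set; compound 2 carries no result in this assay, so compound 1 stands alone and cannot be placed relative to any partner. For the measured compounds named here, no step between two measured compounds is available.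

The unmeasured compound 3, `CNCCCOc1c(Br)cc(-c2c[nH]c(=O)c(Cc3ccc(OC)c(Br)c3)n2)cc1Br`, differs from compound 1 by hydrogen in place of methyl on an amine nitrogen. The change is small: the dimethylamino becomes a methylamino on the same chain, and the rest of the molecule is unchanged. With nothing in the data to show what such a change does to this assay, the account expects no step beyond the usual scatter, in either direction.

On that basis the step of a 1.1-fold lower number from compound 1 to compound 3 (0.03 log units; within the scatter) is expected to be negligible, and compound 3 is estimated at 6500 nM in this assay, within a range from 2500 nM to 16000 nM.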

Compound 3, half-maximal inhibitory concentration: 10900 nM
Compound 3: middle estimate off by 1.7-fold (0.22 log units), on the low side; the measured number falls inside the stated range.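

In this assay, among the compounds shown here, hydrogen in place of methyl on the amine nitrogen gives a 1.6-fold higher number from compound 1 to compound 3 (0.20 log units; within the scatter), the first step between two measured compounds in this set. The dimethylamino and methylamino forms therefore cannot be told apart in this read-out, and this one methyl on the amine nitrogen can be exchanged for hydrogen without a step that leaves the usual scatter, at least for this single pair on the shared core. There is no measurement here that would explain this result, and the reading of the step rests on the two numbers alone.

The compounds shown leave open how the same read-out responds to a primary amine on the same chain, to diethylamino in place of dimethylamino, or to a carboxylic acid in place of the amine. They also leave open whether a longer chain carrying the methylamino would keep the number within the usual scatter of compound 1, since a single step at this position cannot show how far the position tolerates change.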